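Swapping Fluoro for Methyl: A Cell Toxicity Comparison

This account rests on a few compounds, and the source may have more. Where it says the series, first, only, none or still open, it means among the compounds named here.

Of the compounds shown here, three built on closely related cores have been tested in a toxicity assay on WI-38 cells (Homo sapiens) for inhibition, read by MTT assay, with a stated time of 72 h; a higher number here means a weaker inhibitor, a lower number a stronger inhibitor. Compound 1 `Cc1ccc(N2CCCC2)c(C(=O)Nc2ccc(CNC(=O)OCc3cccnc3)cc2)c1` gives 40600 nM in this assay. Compound 2 `O=C(NCc1ccc(NC(=O)c2cc(F)ccc2N2CCCC2)cc1)OCc1cccnc1` reaches only the limit of the assay, reported as > 100000 nM. Compound 3 `O=C(NCc1ccc(NC(=O)c2ccc(F)cc2N2CCCC2)cc1)OCc1cccnc1` likewise stops at the limit, reported as > 100000 nM. Compound 1 and compound 2 differ by a single change, (methyl in place of fluoro on an aromatic carbon), and this change produced an at least 2.4-fold lower number from compound 2 to compound 1 (0.39 log units; beyond the scatter). How the cores of compound 2 and compound 3 differ is not broken down here.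

Compound 4 `Cc1ccc(C(=O)Nc2ccc(CNC(=O)OCc3cccnc3)cc2)c(N2CCCC2)c1` is not yet measured. It is related to compound 3 by methyl in place of fluoro on an aromatic carbon, the same kind of change as that from compound 2 to compound 1, although the surroundings differ: in compound 1 the new group sits meta to a large group and para to a pyrrolidin-1-yl group, while in compound 4 it sits meta to a pyrrolidin-1-yl group and para to a large group. Because (the limit of > 100000 nM in this assay, at which 2 of the 3 values shown sit), the starting point for compound 3 is itself only a limit. Compound 4 is therefore expected to give 60000 nM, between 20000 nM and 150000 nM. The expected step of an at least 1.6-fold lower number from compound 3 to compound 4 (0.22 log units; that floor lies within the scatter) rests on the earlier change alone.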

Compound 4, half-maximal inhibitory concentration: > 100000 nM
Compound 4: only a limit was reported; the forecaster's own chance of this, stated with the estimate: 45%; middle value at least 1.6-fold (0.22 log units) away from the limit.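

No size can be read for the swap of fluoro for methyl from compound 3 to compound 4, because both values are limits: the limit of > 100000 nM in this assay, at which 3 of the 4 values shown sit.

The compounds shown leave open whether this swap, in the surroundings found in compound 4, changes the number in this assay at all, as it does between compound 2 and compound 1.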